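Compound 1 without trifluoromethyl: expected step

The source may report more compounds than this note shows. Statements on the series, on what has been measured and on what is new or still open speak of the compounds shown alone.

Going by the values given here, in a functional assay on SK-N-SH cells (Homo sapiens) for cytotoxicity, read by MTT assay, with a stated time of 24 h (on this read-out lower numbers stand for stronger inhibition and higher numbers for weaker inhibition), compound 1 `O=c1nc2ccccn2cc1Cc1ccc(F)cc1C(F)(F)F` gives 8690 nM, the highest of the three numbers measured so far and beyond the scatter of both others. Compound 2 `Cc1ccc(Cc2cn3cc(Cl)ccc3nc2=O)cc1` gives 860 nM, and compound 3 `O=c1nc2ccc(Cl)cn2cc1Cc1ccc([N+](=O)[O-])cc1` gives 940 nM.

Compound 4 `O=c1nc2ccccn2cc1Cc1ccc(F)cc1` departs from compound 1 in one place: hydrogen in place of trifluoromethyl on an aromatic carbon. This is hydrogen in place of trifluoromethyl on an aromatic carbon, ortho to a large group and meta to a fluoro group.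

Among the compounds with values here, only one measured step bears on this change, and only indirectly: a 1.1-fold higher number from compound 2 to compound 3 (0.04 log units; within the scatter), with nitro in place of methyl on an aromatic carbon. That exchange stays within the scatter, but it involves different groups. Within the data shown here, no measured step removes trifluoromethyl, so the size of this step is poorly constrained. With compound 1 at 8690 nM, the top of the measured numbers, a shift toward a lower number is somewhat more likely than one toward a higher number. A step beyond the scatter is not firmly expected. The estimated step runs a 1.7-fold lower number from compound 1 to compound 4 (0.24 log units; within the scatter). For compound 4 the expected value in this assay is 5000 nM, with an estimated range of 1800 nM to 14000 nM.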

Compound 4, half-maximal inhibitory concentration: 125000 nM
Estimate against measurement, compound 4: 25-fold (1.40 log units) below; measured number above the stated range.
By their numbers in this assay, from the lowest: compounds 2 and 3 (each within the scatter of the next); then compound 1; then compound 4.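

In this assay, hydrogen in place of trifluoromethyl on this aromatic carbon, ortho to a large group and meta to a fluoro group, gives a 14-fold higher number from compound 1 to compound 4 (1.16 log units; beyond the scatter). The only earlier step, a 1.1-fold higher number from compound 2 to compound 3 (0.04 log units; within the scatter), is a different exchange that stays within the scatter, so this is the first step shown in which a single aromatic replacement moves the number beyond the scatter. With the rest of compound 1 unchanged, this position is therefore not indifferent to the change, and the compound carrying trifluoromethyl has the lower number, although this rests on one pair and holds only for compound 1 and compound 4.

The measurements at hand offer no explanation for the size of this step. On these data alone, it remains open whether trifluoromethyl itself is needed or whether another group on this aromatic carbon, such as methoxy or an amine, would keep the number close to that of compound 1, and whether the same replacement would have a step of similar size in compound 2 or compound 3.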